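From a hydroxycyclohexyl arm to a plain oxane ring

The compounds below may be only part of what the source reports. "The series", "measured", "known", "first", "only" and "open" are said of these compounds alone.

Among the compounds with values here, compound 2 `N#Cc1cnc(NCc2cnccc2C(F)(F)F)cc1NC[C@H]1CC[C@H](O)CC1` is the only compound here with a definite number: in an assay on isolated protein for inhibition of protein kinase C delta type (Homo sapiens), read by TR-FRET, with a stated time of 2 h (a lower number here means a stronger inhibitor, a higher number a weaker inhibitor), compound 2 gives 2000 nM. Its close relative compound 1 `N#Cc1cnc(NCc2cnccc2C(F)(F)F)cc1NC[C@H]1C[C@H](O)C1` reaches only a limit of the assay; in this assay compound 1 gives > 10000 nM, and the limit of > 10000 nM in this assay, at which 1 of the 2 values shown sits, records where it sits. Within the data shown here, the one measured step, an at least 5.0-fold lower number from compound 1 to compound 2 (0.69 log units; beyond the scatter), shows that the ring hanging from this nitrogen matters. Compound 3 `N#Cc1cnc(NCc2cnccc2C(F)(F)F)cc1NC1CCOCC1` changes that same position again: oxan-4-yl in place of (4-hydroxycyclohexyl)methyl on a nitrogen on an aromatic ring. Among the measured compounds shown here, both the hydroxy group and the linking methyl carbon go, and nothing measured covers this exact change; the only guidance is that compound 2, carrying the hydroxycyclohexyl arm, already gives 2000 nM. A modest weakening is therefore expected, a 2.0-fold higher number from compound 2 to compound 3 (0.30 log units; within the scatter). Compound 3 is estimated at 4000 nM, with a range from 1000 nM to 15000 nM.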

Compound 3, half-maximal inhibitory concentration: 9800 nM
For compound 3 the middle estimate is 2.5-fold (0.39 log units) below the measured one; measured number inside the range.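

In this assay, oxan-4-yl in place of (4-hydroxycyclohexyl)methyl on a nitrogen on an aromatic ring gives a 4.9-fold higher number from compound 2 to compound 3 (0.69 log units; beyond the scatter), so compound 3 is the weaker inhibitor of this pair. Compound 2 is now the strongest of the three, as its steps to both others lie beyond the scatter. Compound 1 is recorded only as a limit of the assay: the limit of > 10000 nM in this assay, at which 1 of the 3 values shown sits. What remains is an at least 1.0-fold lower number from compound 1 to compound 3 (0.00 log units; that floor lies within the scatter), and this step cannot be read as an order of the two.

This one change removes the hydroxy group and the linking methyl carbon and also puts an oxygen atom into the ring, so the compounds shown do not reveal which of these drives the weakening. They also leave open how an oxan-4-ylmethyl arm, which would restore the linking carbon, or a ring amine such as piperidin-4-yl would behave at this position.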